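Trimethoxyphenyl in place of phenyl on the shared core

The source may hold more compounds than are shown below. What is called first, only, known or untested is meant among the compounds shown, and "the series" means these compounds.

Measured compounds: compound 1 `COc1cc(/C=C/C(=O)c2cccc(-n3cc(-c4ccccc4)[nH]c3=O)c2)ccc1O`, 5290 nM; compound 2 `COc1cc(/C=C/C(=O)c2cccc(-n3cc(-c4ccccc4)[nH]c3=O)c2)cc(OC)c1OC`, 3020 nM; compound 3 `COc1ccc(-c2cn(-c3cccc(C(=O)/C=C/c4ccc(O)c(OC)c4)c3)c(=O)[nH]2)cc1`, 6080 nM.

In a functional assay on TK-10 cells (Homo sapiens) for inhibition (a lower number here means a stronger inhibitor of growth, a higher number a weaker inhibitor of growth), compound 2 gives the lowest of the three numbers, but both gaps, to compound 1 and to compound 3, lie within the scatter, so no order among them is claimed.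

Compound 4 `COc1cc(/C=C/C(=O)c2cccc(-n3cc(-c4cc(OC)c(OC)c(OC)c4)[nH]c3=O)c2)cc(OC)c1OC` differs from compound 2 in one place: 3,4,5-trimethoxyphenyl in place of phenyl on an aromatic carbon.

Among the compounds with values here, the one measured step on that ring, a 1.1-fold higher number from compound 1 to compound 3 (0.06 log units; within the scatter), stayed within the scatter. Compound 2 and compound 1 show numbers within the scatter of each other as well. No step beyond the scatter is therefore expected in this assay, in either direction.

For compound 4 the expected step is a 1.2-fold higher number from compound 2 to compound 4 (0.06 log units; within the scatter), giving an estimate of 3500 nM, within 1500 nM to 8000 nM.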

Compound 4, concentration for 50% growth inhibition: 3000 nM
Estimate against measurement, compound 4: 1.2-fold (0.07 log units) above, and the stated range covers the measured number.
By their numbers in this assay, from the lowest: compounds 4, 2, 1 and 3 (each within the scatter of the next, the first and the last beyond it).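

In this assay the change gives a 1.0-fold lower number from compound 2 to compound 4 (0.00 log units; within the scatter), so on this aromatic carbon of the five-membered ring, 3,4,5-trimethoxyphenyl is tolerated as well as phenyl. The earlier step at this site, a 1.1-fold higher number from compound 1 to compound 3 (0.06 log units; within the scatter), added a single methoxy on another background; this much larger replacement also stays within the scatter. Nothing available explains this flat result.

Going by these compounds, whether an aminomethyl or carboxylic acid group on this aryl ring would move the number beyond the scatter remains open. So does whether 3,4,5-trimethoxyphenyl behaves the same way on the core of compound 1.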